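Moving Two Methoxy Groups on a Weakly Cytotoxic Scaffold

The source may report more compounds than this note shows. Statements on the series, on what has been measured and on what is new or still open speak of the compounds shown alone.

Compound 1 `Cc1ccccc1Nc1nc(SCc2ccc(C(F)(F)F)cc2)nc2ccccc12` carries a 2-methylphenyl group on the nitrogen attached to the shared core. In a functional assay on MDA-MB-231 cells (Homo sapiens) for cytotoxicity, read by MTT assay, with a stated time of 72 h (a lower number here means a stronger inhibitor, a higher number a weaker inhibitor), compound 1 gives 27100 nM. Compound 2 `COc1ccc(Nc2nc(SCc3ccc(C(F)(F)F)cc3)nc3ccccc23)c(OC)c1` carries a 2,4-dimethoxyphenyl group in its place. In this assay compound 2 gives > 50000 nM, which is a limit of the assay and not a number. The step of an at least 1.8-fold higher number from compound 1 to compound 2 (0.26 log units; that floor lies within the scatter) is thus only a floor, and compound 2 stands at the limit of > 50000 nM in this assay, at which 1 of the 2 values shown sits. Compound 3 `COc1cc(Nc2nc(SCc3ccc(C(F)(F)F)cc3)nc3ccccc23)cc(OC)c1` is built from the same atoms as compound 2, joined differently: 3,5-dimethoxyphenyl in place of 2,4-dimethoxyphenyl on a nitrogen on an aromatic ring. For the measured compounds named here, no measured step covers a move of the methoxy groups; the only measured step, an at least 1.8-fold higher number from compound 1 to compound 2 (0.26 log units; that floor lies within the scatter), shows that exchanging the ring on this nitrogen left a weak inhibitor weak. Compound 3 is therefore expected to stay near the edge of what this assay can report, with the step of a number no higher from compound 2 to compound 3 (the limit leaves the size open) expected to lie within the scatter. Compound 3 is estimated at 50000 nM, between 20000 nM and 150000 nM.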

Compound 3, half-maximal inhibitory concentration: 16100 nM
Compound 3: the middle estimate sits 3.1-fold (0.49 log units) above what was measured; measured number outside the range, below it.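

Rearranging the two methoxy groups on the ring on this nitrogen, with the same atoms throughout, is enough to shift the reading in this assay, giving an at least 3.1-fold lower number from compound 2 to compound 3 (0.49 log units; beyond the scatter). Compound 2 stands at a limit of the assay and not at a number, so this step is only a floor: the limit of > 50000 nM in this assay, at which 1 of the 3 values shown sits. Set against the 2-methylphenyl group, however, the 3,5-dimethoxyphenyl group brings no change that can be told from the scatter, giving a 1.7-fold lower number from compound 1 to compound 3 (0.23 log units; within the scatter).

The compounds shown leave open how far the reading can fall through changes on this nitrogen, as all three remain weak inhibitors. A phenyl ring carrying an amine or a carboxylic acid in place of the methoxy groups would test whether this position can support stronger inhibition.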